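The compounds below may be only part of what the source reports. "The series", "measured", "known", "first", "only" and "open" are said of these compounds alone.

Measured in an ADME assay on HEK293 cells (Homo sapiens) for cytotoxicity, read by MTT assay, with a stated time of 48 h; on this read-out lower numbers stand for stronger inhibition and higher numbers for weaker inhibition:
Compound 1 `COc1cccc(-c2nc(SCC(=O)c3sc(-c4ccccc4)nc3C)[nH]c(=O)c2C#N)c1`: 90200 nM
Compound 2 `Cc1nc(-c2ccccc2)sc1C(=O)CSc1nc(-c2ccc(Cl)c(Cl)c2)c(C#N)c(=O)[nH]1`: 85100 nM

Compound 2, at 85100 nM, lies within the scatter of compound 1, so the two cannot be ranked. Compound 3 `Cc1nc(-c2ccccc2)sc1C(=O)CSc1nc(-c2ccccc2)c(C#N)c(=O)[nH]1` differs from compound 2 as follows: phenyl in place of 3,4-dichlorophenyl on an aromatic carbon. That is, it has phenyl in place of 3,4-dichlorophenyl on an aromatic carbon. Among the measured compounds shown here, the one measured step that bears on this, a 1.1-fold lower number from compound 1 to compound 2 (0.03 log units; within the scatter), exchanged the group on that same carbon and stayed within the scatter. No step beyond the scatter is therefore expected in this assay. The expected change is a 1.1-fold higher number from compound 2 to compound 3 (0.02 log units; within the scatter). Compound 3 is estimated at 90000 nM, with a range of 50000 nM to 160000 nM.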

Compound 3, half-maximal inhibitory concentration: 93500 nM
Estimate against measurement, compound 3: 1.0-fold (0.02 log units) below; low and high end bracket the measured number.
By their numbers in this assay, from the lowest: compounds 2, 1 and 3 (each within the scatter of the next).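

In this assay, the bare phenyl group reads the same as both substituted rings: taking off the two chlorines stays within the scatter (a 1.1-fold higher number from compound 2 to compound 3 (0.04 log units; within the scatter)), and so does replacing methoxy with hydrogen (a 1.0-fold higher number from compound 1 to compound 3 (0.02 log units; within the scatter)). Across these three compounds, then, an unsubstituted ring on this aromatic carbon is indistinguishable from 3,4-dichlorophenyl or 3-methoxyphenyl. Nothing presented here accounts for this flat result. The compounds shown leave open whether an amine or a carboxylic acid on this phenyl ring would give a step beyond the scatter.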